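The compounds below may be only part of what the source reports. "The series", "measured", "known", "first", "only" and "open" are said of these compounds alone.

Going by the values given here, compound 2 `C=C1CC[C@@H]2[C@](C)(CNCc3ccco3)[C@H](O)CC[C@@]2(C)[C@@H]1/C=C/C1=CCOC1=O` stands at the higher end of the two numbers so far: in a functional assay on BMMC cells (Mus musculus, strain C57BL/6) for inhibition, with stated times of 5 days and 48 h (on this read-out higher numbers stand for weaker inhibition and lower numbers for stronger inhibition), compound 2 gives 1830 nM, whereas compound 1 `C=C1CC[C@@H]2[C@](C)(CNCc3ccc(Br)cc3)[C@H](O)CC[C@@]2(C)[C@@H]1/C=C/C1=CCOC1=O` gives 430 nM. Among the compounds with values here, the one measured step, a 4.3-fold higher number from compound 1 to compound 2 (0.63 log units; beyond the scatter), placed the furan-2-yl group clearly behind the 4-bromophenyl group. Compound 3 `C=C1CC[C@H]2[C@@](C)(CC[C@@H](O)[C@@]2(C)C(=O)NCc2ccccc2)[C@@H]1/C=C/C1=CCOC1=O` has not yet been measured. It differs from compound 2 as follows: benzylcarbamoyl in place of (((furan-2-yl)methyl)amino)methyl on a saturated ring carbon. Rather than swapping only the aromatic ring, this change also exchanges the amine-linked chain for a benzylcarbamoyl group, so the measured step covers only part of it. Within the data shown here, the return to a six-membered ring of carbon only, as seen in compound 1 at 430 nM, speaks for a somewhat lower number, but the carbamoyl link itself has no precedent here. Compound 3 is therefore expected to land at about 600 nM, within roughly 150 nM to 3000 nM. That expected change, a 3.1-fold lower number from compound 2 to compound 3 (0.48 log units; beyond the scatter), is held loosely.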

Compound 3, half-maximal inhibitory concentration: 19400 nM
Compound 3: middle estimate off by 32-fold (1.51 log units), on the low side; measured number above the stated range.
By their numbers in this assay, from the lowest: compound 1; then compound 2; then compound 3.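

In this assay, benzylcarbamoyl on this saturated ring carbon is far less well accepted than either amine-linked group, with a large rise against the furan compound (an 11-fold higher number from compound 2 to compound 3 (1.03 log units; beyond the scatter)) and a larger one against the bromophenyl compound (a 45-fold higher number from compound 1 to compound 3 (1.65 log units; beyond the scatter)). The earlier step showed only a modest change when one aromatic ring replaced another with the amine link kept, whereas this change shows that a six-membered aromatic ring of carbon only does not by itself keep the number low. Nothing measured here explains the loss.

As far as these compounds go, the change alters the link and the ring together, so their separate shares remain unknown. A (benzylamino)methyl group and a 4-bromobenzylcarbamoyl group on this carbon would be the direct tests of whether the carbamoyl link carries the loss.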